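Shortening the hydroxycarbamoyl chain of compound 1

The source may report more compounds than this note shows. Statements on the series, on what has been measured and on what is new or still open speak of the compounds shown alone.

In a functional assay on CNE-2 cells (Homo sapiens) for inhibition, read by MTT assay, with a stated time of 72 h (a lower number here means a stronger inhibitor, a higher number a weaker inhibitor), compound 1 (`Nc1ncnc2c1c(-c1cnc3[nH]ccc3c1)nn2CCCCC(=O)NO`) gives > 150000 nM, which is a limit of the assay and not a number. Compound 1 therefore stands at the limit of > 150000 nM in this assay, at which 1 of the 3 values shown sits.

Compound 4 (`Nc1ncnc2c1c(-c1cnc3[nH]ccc3c1)nn2CCCC(=O)NO`) differs from it by one change: hydroxycarbamoyl in place of (hydroxycarbamoyl)methyl on a saturated chain carbon, three bonds along the chain from an aromatic nitrogen. Hydroxycarbamoyl takes the place of (hydroxycarbamoyl)methyl on a saturated chain carbon, three bonds along the chain from an aromatic nitrogen, so 4-(hydroxycarbamoyl)butyl becomes 3-(hydroxycarbamoyl)propyl.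

For the measured compounds named here, the only measured chain step sits on a core other than that of compound 1. There, compound 2 (`Nc1nc2cc(-c3nn(CCCCCCCCCC(=O)NO)c4ncnc(N)c34)ccc2o1`) gives 36800 nM and compound 3 (`Nc1nc2cc(-c3nn(CCCCCC(=O)NO)c4ncnc(N)c34)ccc2o1`) gives 37600 nM. The chain change on that core is a 1.0-fold higher number from compound 2 to compound 3 (0.01 log units; within the scatter). Carried across, this step suggests no change beyond the scatter in this assay, although the starting point here is only a limit.

The expected step is a number no higher from compound 1 to compound 4 (the limit leaves the size open). Compound 4 is estimated at 150000 nM, with an expected range of 60000 nM to 400000 nM.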

Compound 4, half-maximal inhibitory concentration: > 150000 nM
Compound 4: only a limit was reported; the forecaster's own chance of this, stated with the estimate: 70%; the middle value lies on the limit itself.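

In this assay compound 4 gives > 150000 nM as a limit of the assay and not a number. Compound 1 also stands at a limit, so no step from compound 1 to compound 4 can be read: the limit of > 150000 nM in this assay, at which 2 of the 4 values shown sit.

The compounds shown leave open whether, in this assay, 3-(hydroxycarbamoyl)propyl and 4-(hydroxycarbamoyl)butyl differ at all on the core of compound 1.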